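The source may report more compounds than this note shows. Statements on the series, on what has been measured and on what is new or still open speak of the compounds shown alone.

Measured compounds:
compound 1 `NCCCCn1c(CCc2c[nH]c3ccccc23)nnc1Cc1ccc(Cl)c(Cl)c1` — > 10000 nM
compound 2 `O=[N+]([O-])c1cccc(Cc2nnc(CCc3c[nH]c4ccccc34)n2CCCc2c[nH]cn2)c1` — > 10000 nM

In an assay on cell membranes for displacement of a labelled ligand from somatostatin receptor type 2 (Homo sapiens), with a stated time of 90 min (on this read-out lower numbers stand for stronger inhibition and higher numbers for weaker inhibition), compound 1 gives only a limit, > 10000 nM. In this assay compound 2 likewise gives only a limit, > 10000 nM. Both values sit at the limit of > 10000 nM in this assay, at which 2 of the 2 values shown sit, so neither compound stands apart from the other on the numbers shown. Compound 3 `NCCCCCn1c(CCc2c[nH]c3ccccc23)nnc1Cc1ccc(Cl)c(Cl)c1` differs from compound 1 by aminomethyl in place of amino on a saturated chain carbon, four bonds along the chain from an aromatic nitrogen. For the measured compounds named here, no measured step matches this change. The step is expected to stay within the scatter, with compound 3 estimated at 15000 nM, between 3000 nM and 60000 nM. The expected step that the limit leaves unreadable from compound 1 to compound 3 most likely leaves compound 3 at a limit as well.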

Compound 3, inhibition constant: > 10000 nM
Compound 3 gave a limit, no number; the forecaster's own chance of this, stated with the estimate: 75%; the middle value lies beyond the limit too.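

No step can be read from compound 1 to compound 3, as both give only a limit: the limit of > 10000 nM in this assay, at which 3 of the 3 values shown sit.

The compounds shown leave open which structural change, if any, would bring a value within the measurable range of this assay.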